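The source may hold more compounds than are shown below. What is called first, only, known or untested is meant among the compounds shown, and "the series" means these compounds.

Measured compounds:
- compound 1, `CN1CCN(CCCOc2cccc3nc(Nc4ccc(Cl)c(C(F)(F)F)c4)ccc23)CC1`: in a functional assay on A549 cells (Homo sapiens) for inhibition, read by sulforhodamine B assay, with a stated time of 48 h (a higher number here means a weaker inhibitor of growth, a lower number a stronger inhibitor of growth), compound 1 gives 1720 nM
- compound 2, `CN1CCN(CCCOc2cccc3nc(Nc4ccc(Cl)c(F)c4)ccc23)CC1`: compound 2 gives 1960 nM
- compound 3, `CN1CCN(CCCOc2cccc3nc(Nc4ccc(F)c(F)c4)ccc23)CC1`: compound 3 gives 3500 nM

All three share one core and differ only in the substituted phenyl ring attached to the nitrogen on the aromatic ring. Compound 3 has the highest number of the three, but one of its two gaps is a 1.8-fold higher number from compound 2 to compound 3 (0.25 log units; within the scatter), within the scatter, while the other is a 2.0-fold higher number from compound 1 to compound 3 (0.31 log units; beyond the scatter), a modest step beyond it.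

Compound 4, `CN1CCN(CCCOc2cccc3nc(Nc4cccc(Cl)c4)ccc23)CC1`, has not yet been measured. The change from compound 3 is 3-chlorophenyl in place of 3,4-difluorophenyl on a nitrogen on an aromatic ring. For the measured compounds named here, two measured steps bear on it. The step of a 1.8-fold higher number from compound 2 to compound 3 (0.25 log units; within the scatter) is the same kind of swap between chlorine and fluorine on an aromatic carbon, and it stayed within the scatter. The step of a 2.0-fold higher number from compound 1 to compound 3 (0.31 log units; beyond the scatter), a larger change of the whole phenyl group, was modest. Together these suggest that putting chlorine back onto the ring may lower the number a little, but no step beyond the scatter is expected.

The estimate for compound 4 in this assay is therefore 2500 nM, with a range of 1200 nM to 5500 nM, which is an expected step of a 1.4-fold lower number from compound 3 to compound 4 (0.15 log units; within the scatter).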

Compound 4, concentration for 50% growth inhibition: 2020 nM
For compound 4 the middle estimate is 1.2-fold (0.09 log units) above the measured one, within the range that was stated.
By their numbers in this assay, from the lowest: compounds 1, 2, 4 and 3 (each within the scatter of the next, the first and the last beyond it).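

In this assay, the single-chlorine ring of compound 4 gives no step beyond the scatter against any of the three earlier rings (a 1.7-fold lower number from compound 3 to compound 4 (0.24 log units; within the scatter); a 1.0-fold higher number from compound 2 to compound 4 (0.01 log units; within the scatter); a 1.2-fold higher number from compound 1 to compound 4 (0.07 log units; within the scatter)). For the compounds shown here, the earlier compounds showed only rings carrying two groups, so this result extends the picture: on this nitrogen, 3-chlorophenyl reads the same, within the scatter, as 3,4-difluorophenyl, 4-chloro-3-fluorophenyl and 4-chloro-3-(trifluoromethyl)phenyl, and the only step beyond the scatter in the set remains the modest one between compound 1 and compound 3. Nothing measured here explains why these rings read so much alike.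

Still open, going by these compounds, is whether this place accepts groups of a different kind, such as a phenyl ring with no substituent at all, or one carrying a methoxy group, an amine or a carboxylic acid, and whether any of these would leave this narrow band of values. Also open, on these data alone, is whether a longer chain at the other end of the molecule would matter more than the ring does.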